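Fluoro Added to the Benzyl Group of Compound 3

The compounds below may be only part of what the source reports. "The series", "measured", "known", "first", "only" and "open" are said of these compounds alone.

Measured compounds:
Compound 1 `Cn1cnc2c(Sc3ccc(F)cc3)ncnc21`: 6%
Compound 2 `Fc1ccc(Cn2cnc3c(Cl)ncnc32)cc1`: 0%
Compound 3 `Fc1ccc(Sc2ncnc3c2ncn3Cc2ccccc2)cc1`: 5%

In an assay on isolated protein for inhibition of Rho-associated protein kinase 1 (Homo sapiens), tested at 30 uM (a higher number here means more inhibition at the concentration tested (going by the name of the read-out), a lower number less inhibition), compound 3 gives 5%. Its number lies close to those of compound 1 and compound 2, within the usual scatter, so the three measured compounds cannot be told apart here. Compound 4 `Fc1ccc(Cn2cnc3c(Sc4ccc(F)cc4)ncnc32)cc1` differs from compound 3 by fluoro in place of hydrogen on an aromatic carbon. Within the data shown here, no measured step concerns a fluoro on this ring; the only step at hand, a number 1 percentage points lower from compound 1 to compound 3 (within the scatter), was a larger change and stayed within the scatter. With all three numbers low and no step beyond the scatter, compound 4 is expected to show a step of no change at the digits printed from compound 3 to compound 4 (within the scatter), nothing beyond the scatter. Compound 4 is therefore estimated at 5%, in the range -5% to 15%.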

Compound 4, a percentage reported as inhibition, at one concentration (the size of the read-out at that concentration, not a potency): 0%
Compound 4: the middle estimate sits 5 percentage points above what was measured, within the range that was stated.
By their numbers in this assay, from the lowest: compounds 2, 4, 3 and 1 (each within the scatter of the next).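

In this assay the change from benzyl to 4-fluorobenzyl (a number 5 percentage points lower from compound 3 to compound 4 (within the scatter)) shows that fluoro at this place, para to a large group, does not separate the two compounds. The other two new steps, (4-fluorophenyl)sulfanyl in place of chloro (no change at the digits printed from compound 2 to compound 4 (within the scatter)) and 4-fluorophenyl in place of hydrogen on the chain carbon (a number 6 percentage points lower from compound 1 to compound 4 (within the scatter)), do not separate their compounds either. No measurement at hand bears on why these numbers stay together.

From the compounds shown here alone, whether an amine or a carboxylic acid at this ring position, or a longer chain on the aromatic nitrogen, would move the number in this assay beyond the scatter remains open.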